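Adding a methoxy to the best-tolerated compound

This account rests on a few compounds, and the source may have more. Where it says the series, first, only, none or still open, it means among the compounds named here.

Going by the values given here, in an ADME assay on Vero cells (Chlorocebus sabaeus) for cytotoxicity, read by MTT assay, with a stated time of 72 h (a lower number here means that less compound is tolerated, a higher number that more compound is tolerated), compound 2 `COc1cccc([C@H](O)COC(=O)/C=C/c2ccccc2)c1` gives 61900 nM and holds the highest of the three numbers so far. In this assay compound 3 `COc1cccc([C@@H](O)COC(=O)/C=C/c2ccccc2)c1` gives 22300 nM and compound 1 `COc1ccccc1[C@H](O)COC(=O)/C=C/c1ccccc1` gives 14000 nM on the same scale. Among the compounds with values here, the one measured step, a 2.8-fold lower number from compound 2 to compound 3 (0.44 log units; beyond the scatter), is modest, and all it rests on is the fact that compounds 2 and 3 differ only in the configuration as drawn in the two structures.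

Compound 4 `COc1cccc([C@H](O)COC(=O)/C=C/c2ccccc2)c1OC` puts methoxy in place of hydrogen on an aromatic carbon, ortho to a large group and ortho to a methoxy group, a change counted as methoxy in place of hydrogen on an aromatic carbon in full. Within the data shown here, no measured step changes a group on an aromatic carbon, so the step to compound 3 is only a rough guide to size. With compound 2 at 61900 nM at the top of the three numbers, a modest fall in this assay seems likelier than a rise, similar to a 2.8-fold lower number from compound 2 to compound 3 (0.44 log units; beyond the scatter) in size. The expected change is a 2.2-fold lower number from compound 2 to compound 4 (0.34 log units; beyond the scatter) on this rough reasoning. For compound 4 the estimated value is 28000 nM, with an expected range from 10000 nM to 70000 nM as its limits.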

Compound 4, half-maximal cytotoxic concentration: 28400 nM
Compound 4: the middle estimate sits 1.0-fold (0.01 log units) below what was measured; low and high end bracket the measured number.
By their numbers in this assay, from the lowest: compounds 1, 3 and 4 (each within the scatter of the next, the first and the last beyond it); then compound 2.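

In this assay, going by these compounds alone, this is the first look at a change on the aromatic ring itself: methoxy in place of hydrogen on an aromatic carbon, ortho to a large group and ortho to a methoxy group, gives a 2.2-fold lower number from compound 2 to compound 4 (0.34 log units; beyond the scatter) and so takes compound 4 away from the top of the series. The same kind of change, reaching compound 4 from a different starting compound, gives a 2.0-fold higher number from compound 1 to compound 4 (0.31 log units; beyond the scatter) and thus runs the opposite way, so across these two modest steps adding a methoxy has no single direction in this assay. Nothing available explains either step, as the only background concerns the drawn configuration of compounds 2 and 3.

Going by these compounds, whether a hydroxyl, an amine or a carboxylic acid on this same aromatic carbon would lower the number as methoxy does in compound 4 remains open. Also open, on these data alone, is whether the drawn configuration at the chain carbon matters as much with two methoxy groups on the ring as it does in a 2.8-fold lower number from compound 2 to compound 3 (0.44 log units; beyond the scatter) with one.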